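The source may hold more compounds than are shown below. What is called first, only, known or untested is meant among the compounds shown, and "the series" means these compounds.

Measured compounds:
- compound 1 `CC(CN)C(C)(CN)C(=O)O`: 1650000 nM
- compound 2 `CC(CN)C(C)CN`: 6100000 nM

In an assay for inhibition of Ornithine decarboxylase (Rattus norvegicus) (on this read-out lower numbers stand for stronger inhibition and higher numbers for weaker inhibition), compound 2 gives the highest of the two numbers, the nearest being compound 1 with its lower value. Compound 3 `CC(CN)C(C)(C)CN` differs from compound 2 by methyl in place of hydrogen on a saturated chain carbon bound to three saturated chain carbons. Among the measured compounds shown here, the only measured step at that same place, a 3.7-fold higher number from compound 1 to compound 2 (0.57 log units; beyond the scatter), removed a carboxy group rather than adding a methyl, so it bears on this change only loosely. No step is expected beyond the scatter, and the estimate for compound 3 is 6000000 nM, between 2000000 nM and 18000000 nM, which means an expected step of a 1.0-fold lower number from compound 2 to compound 3 (0.01 log units; within the scatter).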

Compound 3, inhibition constant: > 10500000 nM
Compound 3 gave a limit, no number; the forecaster's own chance of this, stated with the estimate: 15%; middle value at least 1.7-fold (0.24 log units) from the limit.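

In this assay compound 3 gives a limit and not a number: the limit of > 10500000 nM in this assay, at which 1 of the 3 values shown sits. Methyl in place of hydrogen at this carbon gives an at least 1.7-fold higher number from compound 2 to compound 3 (0.23 log units; that floor lies within the scatter) and so does not separate compound 3 from compound 2 on the floor alone. Methyl in place of carboxy gives an at least 6.3-fold higher number from compound 1 to compound 3 (0.80 log units; beyond the scatter) and so shows that compound 1 stays ahead of this methyl compound as well as the hydrogen compound. Still open, from the compounds shown here alone, is how far the true value of compound 3 lies past its limit, and whether an amine, a hydroxyl or a longer chain on this carbon would match the carboxy group.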